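This account rests on a few compounds, and the source may have more. Where it says the series, first, only, none or still open, it means among the compounds named here.

Measured so far in an ADME assay on HEK-293T cells (Homo sapiens) for cytotoxicity, read by CCK-8 assay, with a stated time of 48 h; on this read-out higher numbers stand for lower toxicity in this test and lower numbers for higher toxicity in this test:

Compound 1 `Cn1cc([S+]([O-])CC(=O)Nc2ccc(Cl)cc2)c2ccccc21`: in this assay compound 1 gives > 100000 nM, which is a limit of the assay rather than a number.
Compound 2 `Cn1cc(SCC(=O)Nc2ccccc2Cl)c2ccccc21`: in this assay compound 2 gives > 100000 nM, again a limit.
Compound 3 `CCOc1ccccc1NC(=O)CSc1c[nH]c2c(Cl)cccc12`: in this assay compound 3 gives > 100000 nM, also a limit.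

Compound 2 therefore stands at the limit of > 100000 nM in this assay, at which 3 of the 3 values shown sit, so no numerical toxicity has been resolved for it or for either companion. Compound 4 `Cn1cc(SCC(=O)Nc2cccc(Cl)c2)c2ccccc21` has not yet been tested in this assay. It differs from compound 2 by 3-chlorophenyl in place of 2-chlorophenyl on an amide-type nitrogen. Among the compounds with values here, no step between measured compounds is available to set a size for this change. Because every measured compound sits at the limit of > 100000 nM in this assay, at which 3 of the 3 values shown sit, the step from a step that the limit leaves unreadable from compound 2 to compound 4 is expected to be none beyond the scatter. Compound 4 is accordingly estimated at 150000 nM, within 70000 nM to 400000 nM.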

Compound 4, half-maximal cytotoxic concentration: > 100000 nM
Compound 4: a limit, no number; the forecaster's own chance of this, stated with the estimate: 85%; the middle value does not contradict the limit.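

Compound 2 and compound 4 each give only a limit, not a number, so no step can be read between them: the limit of > 100000 nM in this assay, at which 4 of the 4 values shown sit.

Left open is whether 3-chlorophenyl and 2-chlorophenyl on an amide-type nitrogen differ at all in this assay.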